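A few compounds are considered here, and "the series" means these few. Any claim that something is new, unique, unknown or untested is made for them only; others in the source may bear on it.

In a functional assay on MCF7 cells (Homo sapiens) for antiproliferative activity, read by sulforhodamine B assay, with a stated time of 48 h (a lower number here means a stronger inhibitor, a higher number a weaker inhibitor), the measured compounds stand as follows:
compound 1 `CCc1ccccc1NS(=O)(=O)c1ccc(N2CCNC2=O)cc1` gives 350 nM;
compound 2 `O=C1NCCN1c1ccc(S(=O)(=O)Nc2ccc(I)cc2)cc1` gives 600 nM;
compound 3 `O=C1NCCN1c1ccc(S(=O)(=O)Nc2ccc(Br)cc2)cc1` gives 240 nM.

Compound 1 sits in the middle of these three numbers, and its two neighbours both lie within the scatter: a 1.7-fold higher number from compound 1 to compound 2 (0.23 log units; within the scatter) and a 1.5-fold lower number from compound 1 to compound 3 (0.16 log units; within the scatter). Compound 4 `O=C1NCCN1c1ccc(S(=O)(=O)Nc2ccccc2)cc1` is not yet measured; compared with compound 1 the change is hydrogen in place of ethyl on an aromatic carbon. Among the measured compounds shown here, no measured pair tests the plain removal of the ethyl without another group entering. The closest guides are the two steps from compound 1, where 4-iodophenyl or 4-bromophenyl in place of 2-ethylphenyl moved the number only within the scatter. A step of similarly small size, if any, is therefore expected for compound 4: a 1.4-fold higher number from compound 1 to compound 4 (0.15 log units; within the scatter). Compound 4 is estimated at 500 nM in this assay, between 200 nM and 1300 nM.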

Compound 4, half-maximal inhibitory concentration: 470 nM
Estimate against measurement, compound 4: 1.1-fold (0.03 log units) above; the measured number falls inside the stated range.
By their numbers in this assay, from the lowest: compounds 3, 1, 4 and 2 (each within the scatter of the next, the first and the last beyond it).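

In this assay, taking the ethyl away with nothing entering in its place gives a 1.3-fold higher number from compound 1 to compound 4 (0.13 log units; within the scatter), so the ethyl is not needed to hold activity at this level. The bare phenyl compound also stays close to both halogen compounds, with a 2.0-fold higher number from compound 3 to compound 4 (0.29 log units; within the scatter) and a 1.3-fold lower number from compound 2 to compound 4 (0.11 log units; within the scatter), even though those two differ from each other beyond the scatter. Nothing available explains why these steps are so small. Going by these compounds, it remains open whether an amine, a carboxylic acid or a longer chain such as butyl on this ring would move the number beyond the scatter.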